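This account rests on a few compounds, and the source may have more. Where it says the series, first, only, none or still open, it means among the compounds named here.

Measured compounds:
- compound 1 `Cc1ccc(C(=O)NCc2ccc(CNS(=O)(=O)c3ccc(C)cc3)cc2)cc1`: 1000 nM
- compound 2 `O=C(NCc1ccc(CNS(=O)(=O)c2ccccc2)cc1)c1ccncc1`: 10 nM
- compound 3 `COc1ccc(C(=O)NCc2ccc(CNS(=O)(=O)c3ccccc3)cc2)cc1`: 1000 nM

In an assay on MDA-MB-231 cells for binding affinity to C-X-C chemokine receptor type 4 (Homo sapiens), read by immunofluorescence and microscopy, with stated times of 10 min and 30 min (on this read-out lower numbers stand for an effect already at smaller amounts and higher numbers for an effect only at larger amounts of compound), compound 3 gives 1000 nM, the same number at the digits shown as compound 1 and together with it the highest of the three; its only step shown is a 100-fold higher number from compound 2 to compound 3 (2.00 log units; beyond the scatter), which swaps the whole aromatic ring on the carbonyl carbon. Compound 4 `Cc1ccc(C(=O)NCc2ccc(CNS(=O)(=O)c3ccccc3)cc2)cc1` differs from compound 3 by a smaller change: methyl in place of methoxy on an aromatic carbon. For the measured compounds named here, no measured step covers this exact exchange. Compound 1, which also carries methyl at this place, sits at 1000 nM, level with compound 3. The step from compound 3 to compound 4 is therefore expected to stay within the scatter, no change at the digits printed from compound 3 to compound 4 (within the scatter). Compound 4 is estimated at 1000 nM, with a range from 300 nM to 3000 nM.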

Compound 4, effective concentration (reported as EC, without a stated level of effect): 100 nM
Compound 4: the middle estimate sits 10-fold (1.00 log units) above what was measured, outside the stated range (below it).
By their numbers in this assay, from the lowest: compound 2; then compound 4; then compounds 1 and 3 (each within the scatter of the next).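

In this assay, the group at this place matters even for a small exchange: a 10-fold lower number from compound 3 to compound 4 (1.00 log units; beyond the scatter), so methoxy and methyl do not count as equal here. The methyl that compound 1 carries at a second place matters too, with a 10-fold lower number from compound 1 to compound 4 (1.00 log units; beyond the scatter), while 4-methylphenyl still falls short of pyridin-4-yl, with a 10-fold higher number from compound 2 to compound 4 (1.00 log units; beyond the scatter).

Going by these compounds, whether a hydroxyl, an amine or a chlorine at this place would give a lower or a higher number stays open. No measurement at hand explains these steps.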